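The compounds below may be only part of what the source reports. "The series", "measured", "known", "first", "only" and "open" are said of these compounds alone.

Measured in an ADME assay on MRC5 cells (Homo sapiens) for cytotoxicity, read by fluorescence and resazurin assay, with a stated time of 3 days; on this read-out lower numbers stand for stronger inhibition and higher numbers for weaker inhibition:
- Compound 1 `Cc1cn(C2CCN(Cc3cccc(OC4CCCC4)c3)CC2)c(=O)[nH]c1=O`: 30300 nM
- Compound 2 `Cc1cn(C2CCN(Cc3cccc(Oc4cccc(F)c4)c3)CC2)c(=O)[nH]c1=O`: > 64000 nM (a limit of the assay, not a number)
- Compound 3 `Cc1cn(C2CCN(Cc3cccc(Oc4ccccc4)c3)CC2)c(=O)[nH]c1=O`: "not determined" (no result reported)

Compound 3 gives no number to start from, as its entry reads "not determined" (no result reported). The next compound, compound 4 `Cc1cn(C2CCN(Cc3cccc(Oc4cccc(C(F)(F)F)c4)c3)CC2)c(=O)[nH]c1=O`, differs from it by one change: trifluoromethyl in place of hydrogen on an aromatic carbon. In words, trifluoromethyl takes the place of hydrogen on an aromatic carbon, meta to a large group.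

Within the data shown here, only one measured step exists in this small set, and it concerns a different change. Replacing cyclopentyl with 3-fluorophenyl on the oxygen gives the step of an at least 2.1-fold higher number from compound 1 to compound 2 (0.32 log units; beyond the scatter). That step is open-ended, and for compound 2 it rests on (the limit of > 64000 nM in this assay, at which 1 of the 3 values shown sits). Among the measured compounds shown here, no measured step adds trifluoromethyl, so no size or direction can be expected for the change from compound 3 in this assay. The estimate therefore rests on the neighbouring values alone. Compound 1 gives 30300 nM, and compound 2 has the closest aromatic group to that of compound 4. Compound 4 is thus expected to show weak inhibition, possibly reaching the limit of this assay. For compound 4 the expected value is 42000 nM, with an estimated range from 17000 nM to 64000 nM.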

Compound 4, half-maximal inhibitory concentration: 12400 nM
The estimate for compound 4 lay 3.4-fold (0.53 log units) above the measured number; measured number below the stated range.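

In this assay, a single change on the aromatic ring carried by the oxygen can move the number downward, something the earlier compounds had not shown: trifluoromethyl in place of fluoro gives an at least 5.1-fold lower number from compound 2 to compound 4 (0.71 log units; beyond the scatter). Going by these compounds, the true size of this step is unknown, since compound 2 stands at a limit of the assay and not at a number: the limit of > 64000 nM in this assay, at which 1 of the 4 values shown sits. The earlier step had gone upward from the cyclopentyl group to 3-fluorophenyl, whereas 3-(trifluoromethyl)phenyl in the same place gives a 2.4-fold lower number from compound 1 to compound 4 (0.39 log units; beyond the scatter), so among these compounds an aromatic ring on the oxygen does not by itself mean a higher number, with compound 2 showing the upward direction and compound 4 the downward one.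

Compound 3 has no reported result, so the step that adds trifluoromethyl to the unsubstituted phenyl ring cannot be read, and it stays unclear how much of the gap between compound 2 and compound 4 comes from gaining trifluoromethyl or from losing fluoro. On these data alone, how a nitrile, a methoxy group or a chlorine in that place would compare with these two groups also remains open.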